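From 4-methoxyphenyl to 3-chlorophenyl in a flat series

The source may hold more compounds than are shown below. What is called first, only, known or untested is meant among the compounds shown, and "the series" means these compounds.

Measured in a functional assay on A549 cells (Homo sapiens) for inhibition, read by sulforhodamine B assay; a higher number here means a weaker inhibitor of growth, a lower number a stronger inhibitor of growth:
Compound 1 `c1ccc(-c2ccc(-c3ccc(-c4nc5ccccc5[nH]4)cc3)cc2)cc1`: 41200 nM
Compound 2 `Oc1ccc(-c2ccc(-c3ccc(-c4nc5ccccc5[nH]4)cc3)cc2)cc1`: 33100 nM
Compound 3 `COc1ccc(-c2ccc(-c3ccc(-c4nc5ccccc5[nH]4)cc3)cc2)cc1`: 38100 nM

Compound 3 at 38100 nM lies within the scatter of both other compounds, so the three cannot be ranked. Compound 4 `Clc1cccc(-c2ccc(-c3ccc(-c4nc5ccccc5[nH]4)cc3)cc2)c1` carries 3-chlorophenyl in place of 4-methoxyphenyl on an aromatic carbon, para to a large group (3-chlorophenyl in place of 4-methoxyphenyl on an aromatic carbon). Among the compounds with values here, three measured steps bear on this change. Hydroxy in place of hydrogen gave a 1.2-fold lower number from compound 1 to compound 2 (0.10 log units; within the scatter), methoxy in place of hydrogen gave a 1.1-fold lower number from compound 1 to compound 3 (0.03 log units; within the scatter), and methyl in place of hydrogen on the oxygen gave a 1.2-fold higher number from compound 2 to compound 3 (0.06 log units; within the scatter). All three stay within the scatter. Within the data shown here, none of the measured compounds carries chlorine, so the evidence is indirect, and the range is kept wide. In this assay no change beyond the scatter is therefore expected, and the expected step is a 1.2-fold lower number from compound 3 to compound 4 (0.08 log units; within the scatter). For compound 4 the estimate is 32000 nM, with an expected range from 14000 nM to 62000 nM.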

Compound 4, concentration for 50% growth inhibition: 31100 nM
For compound 4 the middle estimate is 1.0-fold (0.01 log units) above the measured one; measured number inside the range.
By their numbers in this assay, from the lowest: compounds 4, 2, 3 and 1 (each within the scatter of the next).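

In this assay, within the data shown here, the first chlorine-bearing ring on the shared core gives a 1.2-fold lower number from compound 3 to compound 4 (0.09 log units; within the scatter) and a 1.1-fold lower number from compound 2 to compound 4 (0.03 log units; within the scatter) and also a 1.3-fold lower number from compound 1 to compound 4 (0.12 log units; within the scatter) with no step leaving the scatter. The earlier compounds shown here had tested only hydroxy and methoxy against hydrogen, whereas here the flat picture also holds for 3-chlorophenyl, a group with no hydrogen-bond acceptor and with its substituent at a different place on the ring from 4-methoxyphenyl. Nothing available explains why these four groups cannot be told apart in this assay.

As far as these compounds go, whether an amine, a carboxylic acid or a longer chain on this ring would take the number beyond the scatter remains open. The compounds shown also leave open whether chlorine at the place held by methoxy in compound 3 would behave like the 3-chlorophenyl group, and whether any change elsewhere on the shared core would matter more.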